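The source may report more compounds than this note shows. Statements on the series, on what has been measured and on what is new or still open speak of the compounds shown alone.

In an ADME assay on microsomes from liver (Homo sapiens) for metabolic stability (on this read-out lower numbers stand for slow clearance and higher numbers for fast clearance), compound 1 (`NC1=N[C@@]2(c3cc(NC(=O)c4cnc(OCF)cn4)ccc3F)COCC[C@H]2CC1(F)F`) gives 46.2 mL.min-1.g-1, and compound 2 (`NC1=N[C@@]2(c3cc(NC(=O)c4cnc(OCF)cn4)ccc3F)CCOC[C@H]2CC1(F)F`) gives 35.3 mL.min-1.g-1. For the measured compounds named here, these two numbers lie within the usual scatter of each other, so compound 1 cannot be separated from the only other measured compound, and the pair marks out a single level of clearance for this series.

Compound 3 (`C[C@H]1C[C@H]2CC(F)(F)C(N)=N[C@@]2(c2cc(NC(=O)c3cnc(OCF)cn3)ccc2F)CO1`) has not yet been measured. It departs from compound 1 at one place: methyl in place of hydrogen on a saturated ring carbon. In words, this is methyl in place of hydrogen on a saturated ring carbon, next to the ring oxygen, while the rest of the core of compound 1 stays the same.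

Going by the values given here, no measured pair shows what such a methyl does in this assay, so there is no direct precedent, and the expectation stays cautious, with no step beyond the scatter in either direction. The estimated 1.1-fold lower number from compound 1 to compound 3 (0.04 log units; within the scatter) is therefore small and is expected to stay within the scatter. For compound 3 the expected value is 42 mL.min-1.g-1, with an estimated range from 21 mL.min-1.g-1 to 80 mL.min-1.g-1.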

Compound 3, intrinsic clearance in microsomes: 119 mL.min-1.g-1
Beside the measured number, compound 3's estimate is 2.8-fold (0.45 log units) below it; measured number above the stated range.
By their numbers in this assay, from the lowest: compounds 2 and 1 (each within the scatter of the next); then compound 3.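

In this assay the methyl on a saturated ring carbon, next to the ring oxygen, is not a silent addition: a 2.6-fold higher number from compound 1 to compound 3 (0.41 log units; beyond the scatter) is the first step shown in this series, and it points towards faster clearance. The earlier compounds shown here gave only a single level of clearance and said nothing about substitution on this ring carbon, whereas this one pair shows that the read-out responds to the addition of one carbon atom at this position, even if the step is only modest. Nothing measured here accounts for the rise, so the reason for it remains unknown.

The compounds shown leave open whether the step belongs to methyl in particular, or whether an ethyl group, a hydroxymethyl group or a fluorine atom on the same carbon would move clearance in the same direction and by a similar amount. They also leave open whether the opposite arrangement of the methyl on this carbon, or a methyl on another saturated ring carbon of the core of compound 1, would give a comparable step.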